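The source may hold more compounds than are shown below. What is called first, only, known or untested is meant among the compounds shown, and "the series" means these compounds.

Working notes on the amide series, read in a functional assay on PC-3 cells (Homo sapiens) for antiproliferative activity, read by MTT assay, with a stated time of 24 h; a higher number here means a weaker inhibitor, a lower number a stronger inhibitor. Compound 1 `CCn1c(C(=O)NCC(=O)OC)ccc1C(CC)(CC)c1ccc(OCS(=O)(=O)c2ccccc2)c(C)c1` stands at > 50000 nM, which is a limit of the assay. Compound 2 `CCn1c(C(=O)NC2(CO)CC2)ccc1C(CC)(CC)c1ccc(OCS(=O)(=O)c2ccccc2)c(C)c1` gives 3560 nM. Compound 3 `CCn1c(C(=O)N[C@H](CO)C(C)C)ccc1C(CC)(CC)c1ccc(OCS(=O)(=O)c2ccccc2)c(C)c1` gives 7300 nM, the higher of the two numbers. Compound 4 `CCn1c(C(=O)N[C@@H](CO)C(C)C)ccc1C(CC)(CC)c1ccc(OCS(=O)(=O)c2ccccc2)c(C)c1` differs from compound 3 as follows: the two compounds have the same atoms and bonds and differ only in configuration as drawn: 1 of 1 stereo elements differ; a stereocentre at a saturated chain carbon is drawn S in compound 3 and R in compound 4. Going by the values given here, no measured step changes configuration alone. The changes on the amide-type nitrogen bear on it only indirectly: an at least 14-fold lower number from compound 1 to compound 2 (1.14 log units; beyond the scatter), an at least 6.8-fold lower number from compound 1 to compound 3 (0.83 log units; beyond the scatter) and a 2.1-fold higher number from compound 2 to compound 3 (0.31 log units; beyond the scatter). The last, between the two hydroxymethyl substituents, is the closest guide, so a step of at most modest size is expected in this assay, with no direction favoured. The estimated step is a 1.0-fold lower number from compound 3 to compound 4 (0.02 log units; within the scatter). Compound 4 is expected at 7000 nM, within an estimated range of 2500 nM to 22000 nM.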

Compound 4, half-maximal inhibitory concentration: 10600 nM
Beside the measured number, compound 4's estimate is 1.5-fold (0.18 log units) below it; low and high end bracket the measured number.
By their numbers in this assay, from the lowest: compound 2; then compounds 3 and 4 (each within the scatter of the next). At a limit, above all of these: compound 1.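

In this assay, going by these compounds alone, the S and R forms at the stereocentre of the 1-(hydroxymethyl)-2-methylpropyl amide are not separated, with a 1.5-fold higher number from compound 3 to compound 4 (0.16 log units; within the scatter) as the first step on configuration alone. Compound 2 now stands clear of the R form as well, with a 3.0-fold higher number from compound 2 to compound 4 (0.47 log units; beyond the scatter) on replacing 1-(hydroxymethyl)cyclopropyl. The (methoxycarbonyl)methyl amide stays behind in either configuration, with an at least 4.7-fold lower number from compound 1 to compound 4 (0.67 log units; beyond the scatter) measured from a limit of the assay.

Still open, on these data alone, is how a carboxylic acid or a primary amine in place of the hydroxymethyl would read, and whether configuration counts with a longer chain on the stereocentre.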